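The source may report more compounds than this note shows. Statements on the series, on what has been measured and on what is new or still open speak of the compounds shown alone.

Measured so far:
- compound 2 `COc1ccc(/C=C/C(=O)c2cccc(-c3cccc(F)c3)c2)cc1OC`: in an assay on A549 cells for inhibition of transcription factor p65 (Homo sapiens), read by fluorescence, with a stated time of 2 h (a higher number here means a weaker inhibitor, a lower number a stronger inhibitor), compound 2 gives 33400 nM
- compound 1 `COc1ccc(/C=C/C(=O)c2cccc(-c3ccc(F)cc3)c2)cc1`: in this assay compound 1 reaches only a limit, > 50000 nM

Among the measured compounds shown here, compound 2 holds the only numbered value in the set; the other entry is the limit of > 50000 nM in this assay, at which 1 of the 2 values shown sits, not a number. Compound 3 `COc1ccc(/C=C/C(=O)c2cccc(-c3ccc(F)cc3)c2)cc1OC` carries 4-fluorophenyl in place of 3-fluorophenyl on an aromatic carbon. For the measured compounds named here, no measured pair isolates this change, so nothing beyond the scatter is expected in this assay, in either direction. Compound 3 is expected near 40000 nM, with a range from 15000 nM to 100000 nM. The step of a 1.2-fold higher number from compound 2 to compound 3 (0.08 log units; within the scatter) is expected to stay within the scatter.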

Compound 3, half-maximal inhibitory concentration: > 50000 nM
Compound 3 ended at the assay's limit; the forecaster's own chance of this, stated with the estimate: 35%; middle value at least 1.2-fold (0.09 log units) away from the limit.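

Placing 4-fluorophenyl in place of 3-fluorophenyl, on an aromatic carbon meta to a large group, gives an at least 1.4-fold higher number from compound 2 to compound 3 (0.17 log units; that floor lies within the scatter). Compound 3 stands at a limit of this assay, not at a number, so this pair sets only a floor and the true step may be larger. The step between compound 1 and compound 3, methoxy in place of hydrogen, cannot be read, as both values are limits.

On these data alone, whether an amine or a carboxylic acid on this ring would give a lower number stays open. The true size of the fluorine step also stays open, with most of the set at one limit: the limit of > 50000 nM in this assay, at which 2 of the 3 values shown sit.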